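Pyrazole swap on the shared core, compound 2 to 3

The compounds below may be only part of what the source reports. "The series", "measured", "known", "first", "only" and "open" are said of these compounds alone.

Values in a functional assay on A-375 cells (Homo sapiens) for inhibition, read by sulforhodamine B assay, with a stated time of 6 days; on this read-out higher numbers stand for weaker inhibition and lower numbers for stronger inhibition:
- compound 1 `CNCCNCc1cccc(-c2nc(NC3CCOCC3)c(C)c(-c3ccnc4[nH]ccc34)n2)c1`: 18200 nM
- compound 2 `CNCCNCc1cccc(-c2nc(NC3CCOCC3)c(C)c(-c3c(C)nn(C)c3C)n2)c1`: > 50000 nM (a limit, not a number)

Compound 2 stands at the limit of > 50000 nM in this assay, at which 1 of the 2 values shown sits. Compound 3 `CNCCNCc1cccc(-c2nc(NC3CCOCC3)c(C)c(-c3ccnn3C)n2)c1` carries a change from it: 1-methyl-1H-pyrazol-5-yl in place of 1,3,5-trimethyl-1H-pyrazol-4-yl on an aromatic carbon. Among the compounds with values here, the one measured step at this carbon is an at least 2.7-fold higher number from compound 1 to compound 2 (0.43 log units; beyond the scatter), and that step ends on the limit, so its full size is unknown. Both compound 2 and compound 3 keep one five-membered aromatic ring with 2 hetero atoms here, so no step beyond the scatter is firmly expected in this assay, and no direction is favoured. The expected change is an at least 1.1-fold lower number from compound 2 to compound 3 (0.04 log units; that floor lies within the scatter). Compound 3 is estimated at 45000 nM, with a range of 20000 nM to 100000 nM.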

Compound 3, half-maximal inhibitory concentration: > 50000 nM
Compound 3: only a limit was reported; the forecaster's own chance of this, stated with the estimate: 60%; middle value at least 1.1-fold (0.04 log units) from the limit.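

In this assay, a second pyrazole, 1-methyl-1H-pyrazol-5-yl, also falls short of the group on compound 1, giving an at least 2.7-fold higher number from compound 1 to compound 3 (0.43 log units; beyond the scatter). The shortfall at this carbon is therefore not confined to 1,3,5-trimethyl-1H-pyrazol-4-yl. The step between compound 2 and compound 3 cannot be read, because both end on the same limit: the limit of > 50000 nM in this assay, at which 2 of the 3 values shown sit.

As far as these compounds go, how far either pyrazole lies past that limit stays open. Also open, from the compounds shown here alone, is whether a plain phenyl or a pyridin-4-yl on this carbon would keep the number nearer that of compound 1.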